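Biphenyl-type series: aryl replacement on the weakest member

The source may hold more compounds than are shown below. What is called first, only, known or untested is meant among the compounds shown, and "the series" means these compounds.

Working notes on a small set of amides built on the shared core of compound 1, `CC(C)C[C@H](N)CCN(C(=O)[C@@H]1C[C@H]1c1ccccc1)c1ccc(-c2ccccc2)cc1`, all read in a functional assay for agonist activity at G protein-coupled receptor 88 (Homo sapiens), read by HTRF and cAMP accumulation; on this read-out higher numbers stand for an effect only at larger amounts of compound and lower numbers for an effect already at smaller amounts. Compound 1 gives 3 nM. Among the measured compounds shown here, compound 2, `CCC(C)CNCCN(C(=O)[C@@H]1C[C@H]1c1ccccc1)c1ccc(-c2ccccc2)cc1`, gives 4.7 nM; the only single-point step available, a 1.6-fold higher number from compound 1 to compound 2 (0.19 log units; within the scatter), concerns the amine-bearing chain and not the aryl part. Compound 3, `CC(C)C[C@H](N)CN(C(=O)[C@@H]1C[C@H]1c1ccccc1)c1ccc(-c2ccncc2)cc1`, gives 13000 nM, the highest number of the three, far beyond the scatter from both compound 1 and compound 2; it differs from compound 1 in two places at once, so its two values show only the overall gap.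

Compound 4, `COc1ccccc1-c1ccc(N(C[C@@H](N)CC(C)C)C(=O)[C@@H]2C[C@H]2c2ccccc2)cc1`, is compound 3 with 2-methoxyphenyl in place of pyridin-4-yl on an aromatic carbon. For the measured compounds named here, no measured step addresses this aryl exchange; the one measured step is of a different kind and small. The expectation rests on the two compounds whose cores carry a plain phenyl ring: compound 1 at 3 nM and compound 2 at 4.7 nM, set against compound 3 with its pyridin-4-yl at 13000 nM. A large move toward lower numbers is therefore expected for compound 4, a 130-fold lower number from compound 3 to compound 4 (2.11 log units; beyond the scatter), though its shorter chain and the added methoxy leave the size uncertain. Compound 4 is estimated at 100 nM, within 10 nM to 1500 nM.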

Compound 4, half-maximal effective concentration: 3200 nM
Compound 4: middle estimate off by 32-fold (1.51 log units), on the low side, outside the stated range (above it).
By their numbers in this assay, from the lowest: compounds 1 and 2 (each within the scatter of the next); then compound 4; then compound 3.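

In this assay, an aryl exchange on an aromatic carbon para to a large group can now be read on its own, a 4.1-fold lower number from compound 3 to compound 4 (0.61 log units; beyond the scatter) and this step is beyond the scatter yet modest. With the amine-bearing chain held constant, 2-methoxyphenyl in place of pyridin-4-yl gives a real but limited shift, and compound 4 still reads 3200 nM on this chain. Among the compounds shown here, the single step combines two changes, the loss of the ring nitrogen and the arrival of the methoxy group, and no measured evidence bearing on the size of this step is at hand.

The compounds shown leave open how much of the distance between compound 3 and compound 1 belongs to the aryl group and how much to the chain, since a plain phenyl on the shorter chain and a pyridin-4-yl on the longer chain would each be needed to divide it. Also open, on these data alone, is how 3-methoxyphenyl, 4-methoxyphenyl or pyridin-3-yl would read at this same place, which would show whether the position of the methoxy group or of the ring nitrogen matters here.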